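Removing the Bromo Group from Compound 2

This account rests on a few compounds, and the source may have more. Where it says the series, first, only, none or still open, it means among the compounds named here.

Measured in a functional assay on PC-3 cells (Homo sapiens) for cytotoxicity, read by MTT assay, with a stated time of 72 h; a higher number here means a weaker inhibitor, a lower number a stronger inhibitor
Compound 1 `O=C(N/N=C/c1cccc(Br)c1)Nc1cc2c(Nc3ccc(F)c(Cl)c3)ncnc2cc1O[C@H]1CCOC1` gives 15500 nM
Compound 2 `O=C(N/N=C/c1ccc(O)c(Br)c1)Nc1cc2c(Nc3ccc(F)c(Cl)c3)ncnc2cc1O[C@H]1CCOC1` gives 5230 nM

Of these two, compound 2 has the lower number and is the stronger inhibitor. Compound 3 `O=C(N/N=C/c1ccc(O)cc1)Nc1cc2c(Nc3ccc(F)c(Cl)c3)ncnc2cc1O[C@H]1CCOC1` differs from it by hydrogen in place of bromo on an aromatic carbon, so hydrogen takes the place of bromo. Among the measured compounds shown here, the only measured step, a 3.0-fold lower number from compound 1 to compound 2 (0.47 log units; beyond the scatter), added a hydroxy group and removed no bromo, so it offers only a loose guide to size. No measurement shows what losing bromo does, which leaves the direction uncertain. A small rise is expected in this assay, namely a 1.5-fold higher number from compound 2 to compound 3 (0.18 log units; within the scatter). For compound 3 the estimate is 8000 nM, within a range of 2500 nM to 22000 nM.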

Compound 3, half-maximal inhibitory concentration: 4890 nM
Compound 3: the middle estimate sits 1.6-fold (0.21 log units) above what was measured; low and high end bracket the measured number.
By their numbers in this assay, from the lowest: compounds 3 and 2 (each within the scatter of the next); then compound 1.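

In this assay, going from the 3-bromo-4-hydroxyphenyl group to the 4-hydroxyphenyl group gives a 1.1-fold lower number from compound 2 to compound 3 (0.03 log units; within the scatter) at this position, ortho to a hydroxy group, so bromo and hydrogen cannot be told apart here. With the hydroxy group present and no bromo at all, the change of 3-bromophenyl to 4-hydroxyphenyl still gives a 3.2-fold lower number from compound 1 to compound 3 (0.50 log units; beyond the scatter) in this comparison. No outside measurement is available to explain these results.

From the compounds shown here alone, what an amine, a methoxy group or a chlorine at this position would do remains open. Whether bromo counts for as little without the hydroxy group is also unresolved.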